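Replacing a butyl chain with benzyl on a fucosidase inhibitor

The source may report more compounds than this note shows. Statements on the series, on what has been measured and on what is new or still open speak of the compounds shown alone.

Measured so far in an assay on isolated protein (Bos taurus) for inhibition of tissue alpha-L-fucosidase (Homo sapiens); on this read-out higher numbers stand for weaker inhibition and lower numbers for stronger inhibition:
compound 1 `CCCCNC1CC(C)C(O)C(O)C1O` gives 920 nM;
compound 2 `CCCCCCCCCNC1CC(C)C(O)C(O)C1O` gives 240 nM.

Compound 1 stands at the higher of these two numbers. Going by the values given here, the one step on record, a 3.8-fold lower number from compound 1 to compound 2 (0.58 log units; beyond the scatter), shows that a longer chain on the amine brought a lower number. Compound 3 `CC1CC(NCc2ccccc2)C(O)C(O)C1O` differs from compound 1 by phenyl in place of propyl on a saturated chain carbon bound to an amine nitrogen. That step is not the same as lengthening the chain, so the measured step only hints that a larger group there can help. A small lowering in this assay is therefore expected, a 1.5-fold lower number from compound 1 to compound 3 (0.19 log units; within the scatter), with wide uncertainty. Compound 3 is estimated at 600 nM, between 150 nM and 2500 nM.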

Compound 3, half-maximal inhibitory concentration: 1000 nM
Compound 3: the middle estimate sits 1.7-fold (0.22 log units) below what was measured, and the stated range covers the measured number.
By their numbers in this assay, from the lowest: compound 2; then compounds 1 and 3 (each within the scatter of the next).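

In this assay, phenyl in place of propyl on a saturated chain carbon bound to an amine nitrogen gives a 1.1-fold higher number from compound 1 to compound 3 (0.04 log units; within the scatter), so compound 1 and compound 3 cannot be told apart. The lower number that came with the longer chain in a 3.8-fold lower number from compound 1 to compound 2 (0.58 log units; beyond the scatter) therefore does not carry over to this aromatic ring. Nothing measured here gives a reason for this result.

Still open, as far as these compounds go, is how a phenylethyl group on the amine nitrogen would compare, with its ring set further along a chain. A methoxy group on the phenyl ring is equally untested by these compounds.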